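One Methoxy Fewer on the Shared Core

The source may hold more compounds than are shown below. What is called first, only, known or untested is meant among the compounds shown, and "the series" means these compounds.

Of the compounds shown here, three built on the same core have been measured in a functional assay on HOP-62 cells (Homo sapiens) for cytotoxicity, read by sulforhodamine B assay, with a stated time of 48 h, tested at 0.1 uM; on this read-out higher numbers stand for a weaker effect at the one concentration tested and lower numbers for a stronger effect. Compound 1 `COc1cc(-c2cc(/C=C/C(=O)c3ccc(N)cc3)[nH]n2)cc(OC)c1OC` gives 92%, compound 2 `COc1ccc(-c2cc(/C=C/C(=O)c3ccc(OC)c(OC)c3)[nH]n2)cc1` gives 97%, and compound 3 `COc1cc(-c2cc(/C=C/C(=O)c3ccc(Cl)c(Cl)c3)[nH]n2)cc(OC)c1OC` gives 101%. Within the data shown here, compound 1 has the lowest number of the three, but its gaps to compound 2 and to compound 3 both lie within the usual scatter, so the three values cannot be told apart; the one single-point step, a number 9 percentage points higher from compound 1 to compound 3 (within the scatter), is also within the scatter and says that swapping the group on the carbonyl carbon leaves this read-out essentially unchanged at the concentration tested.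

Compound 4 `COc1ccc(-c2cc(/C=C/C(=O)c3ccc(N)cc3)[nH]n2)cc1OC` has not yet been measured. It differs from compound 1 by hydrogen in place of methoxy on an aromatic carbon. The methoxy that leaves sits ortho to a methoxy group and meta to a large group, on the ring carried by the shared core rather than on the carbonyl side. Among the measured compounds shown here, none of the measured steps touches that ring, so no direct guide exists; the only evidence is that every change seen so far stayed within the scatter. The expected step of a number 3 percentage points higher from compound 1 to compound 4 (within the scatter) is therefore none beyond the scatter, and compound 4 is estimated at 95%, between 84% and 106%.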

Compound 4, a percentage reported as activity, at one concentration (the size of the read-out at that concentration, not a potency): 91%
Estimate against measurement, compound 4: 4 percentage points above; the range from low to high includes it.
By their numbers in this assay, from the lowest: compounds 4, 1, 2 and 3 (each within the scatter of the next).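

Among these compounds, this is the first single-place step on the methoxy-bearing ring rather than on the carbonyl side: in this assay, hydrogen in place of methoxy gives a number 1 percentage points lower from compound 1 to compound 4 (within the scatter) and stays within the scatter. The methoxy ortho to a methoxy group and meta to a large group can therefore leave without a change that this read-out can separate from ordinary repeat variation at the one concentration tested, so the flat picture now extends from the carbonyl side to this ring. No accompanying measurement bears on why this position behaves this way, so the step stands as an observation without an explanation.

A single concentration at which all four compounds give similar numbers leaves open whether the methoxy matters at higher concentrations, where differences between compound 1 and compound 4 might appear. It also leaves open whether a different group on this aromatic carbon, such as a hydroxyl, an ethoxy or a longer alkoxy chain, would move the read-out beyond the scatter.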